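Oxazole in Place of Thiazole on a Shared Core

This account rests on a few compounds, and the source may have more. Where it says the series, first, only, none or still open, it means among the compounds named here.

Compound 1 `O=C(O)c1cc(-c2cccs2)ccc1O` and compound 2 `O=C(O)c1cc(-c2ccns2)ccc1O` share one core and differ only in the five-membered heteroaryl group attached to it. In a functional assay on the whole organism for inhibition, with Rattus norvegicus as the target, read by paw edema (on this read-out lower numbers stand for an effect already at smaller amounts and higher numbers for an effect only at larger amounts of compound), compound 1 gives 60 mg/kg. In this assay compound 2 gives 80 mg/kg. Among the measured compounds shown here, the single measured step, a 1.3-fold higher number from compound 1 to compound 2 (0.12 log units; within the scatter), leaves compound 2 not separated from compound 1 beyond the scatter, so neither stands apart on this read-out. Compound 3 `O=C(O)c1cc(-c2ccno2)ccc1O` is not yet measured; it differs from compound 2 by 1,2-oxazol-5-yl in place of 1,2-thiazol-5-yl on an aromatic carbon. For the measured compounds named here, no measured step bears directly on this exchange; the nearest precedent, one five-membered heteroaryl swapped for another in a 1.3-fold higher number from compound 1 to compound 2 (0.12 log units; within the scatter), stayed within the scatter. On that basis the step from compound 2 to compound 3 is expected to be a 1.1-fold higher number from compound 2 to compound 3 (0.05 log units; within the scatter), nothing beyond the scatter in either direction. Compound 3 is therefore estimated at 90 mg/kg in this assay, with a range from 45 mg/kg to 180 mg/kg.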

Compound 3, dose for half-maximal effect: 110 mg/kg
Estimate against measurement, compound 3: 1.2-fold (0.09 log units) below, and the stated range covers the measured number.
By their numbers in this assay, from the lowest: compounds 1, 2 and 3 (each within the scatter of the next).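

The exchange of 1,2-thiazol-5-yl for 1,2-oxazol-5-yl on the shared core gives a 1.4-fold higher number from compound 2 to compound 3 (0.14 log units; within the scatter) in this assay, and the replacement of thiophen-2-yl by 1,2-oxazol-5-yl gives a 1.8-fold higher number from compound 1 to compound 3 (0.26 log units; within the scatter). Both steps stay within the scatter, so the three five-membered heteroaryl groups at this position, meta to the carboxy group and para to the hydroxy group, are not separated on this read-out, even across the widest pair now available. No measurement available speaks to what lies behind these numbers.

On these data alone, all three compounds carry a five-membered aromatic ring at this position, so whether an amine or a longer chain there would give a number beyond the scatter remains open. Also open, as far as these compounds go, is how an amide in place of the carboxy group would read in this assay.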